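The source may report more compounds than this note shows. Statements on the series, on what has been measured and on what is new or still open speak of the compounds shown alone.

Compound 1 `CNC(=O)c1cnc(N2CCN(C3CCN(Cc4ccc(Cl)cc4)CC3)C(C(=O)OC)C2)c(Cl)c1` and compound 2 `CNC(=O)c1cnc(N2CCN(C3CCN(Cc4ccc(Cl)cc4)CC3)C(COC)C2)c(Cl)c1` share one core and differ in a single group on a saturated ring carbon. In a functional assay for antagonist activity at C-X-C chemokine receptor type 3 (Homo sapiens) (on this read-out higher numbers stand for weaker inhibition and lower numbers for stronger inhibition), compound 1 gives 140 nM, while compound 2 gives 3100 nM; the change a 22-fold higher number from compound 1 to compound 2 (1.35 log units; beyond the scatter) is therefore large. Within the data shown here, on these two numbers compound 2 stands as the weaker of the pair, its only neighbour being compound 1, which sits well below it.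

Compound 3 `CNC(=O)c1cnc(N2CCN(C3CCN(Cc4ccc(Cl)cc4)CC3)C(C(=O)O)C2)c(Cl)c1` has not yet been measured. Its difference from compound 2 is carboxy in place of methoxymethyl on a saturated ring carbon. Among the measured compounds shown here, the one measured step that bears on this change is the replacement of the methoxycarbonyl of compound 1 by the methoxymethyl of compound 2, which weakened inhibition strongly. The carboxy group of compound 3 brings back a carbonyl in that same place, so part of that step is undone, though the methyl of the ester is not restored. A step downward in this assay of moderate size, a 3.9-fold lower number from compound 2 to compound 3 (0.59 log units; beyond the scatter), is expected, landing between the two measured values. The estimate for compound 3 is 800 nM, with a range from 150 nM to 5000 nM.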

Compound 3, half-maximal inhibitory concentration: > 50000 nM
Compound 3 ended at the assay's limit; the forecaster's own chance of this, stated with the estimate: 10%; at least 62-fold (1.79 log units) between middle value and limit.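

In this assay the result for compound 3 is a limit and not a number: the limit of > 50000 nM in this assay, at which 1 of the 3 values shown sits. Even read as a limit, carboxy in place of methoxymethyl on this saturated ring carbon gives an at least 16-fold higher number from compound 2 to compound 3 (1.20 log units; beyond the scatter), so bringing a carbonyl back to this place does not by itself restore the inhibition seen with compound 1. The sharper lesson comes from the smallest edit in the set, hydrogen in place of methyl on an oxygen next to a carbonyl group, which gives an at least 350-fold higher number from compound 1 to compound 3 (2.55 log units; beyond the scatter) and shows that this position responds very strongly to a change of a single methyl on the ester.

From the compounds shown here alone, how far compound 3 lies beyond the limit stays open. Three compounds cannot separate the loss of the ester methyl from the arrival of the free carboxy hydrogen. A primary amide, an ethyl ester or a longer ester chain on the same ring carbon would show whether the methyl is needed as such or whether any group capping that carbonyl will serve.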